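Methyl on the amide nitrogen of compound 3

The compounds below may be only part of what the source reports. "The series", "measured", "known", "first", "only" and "open" are said of these compounds alone.

Measured so far in an ADME assay on HEK293 cells (Homo sapiens) for cytotoxicity, read by resazurin assay, with a stated time of 72 h (on this read-out higher numbers stand for lower toxicity in this test and lower numbers for higher toxicity in this test), are three compounds:
- Compound 1 `O=C(O)c1ccc(CCOc2c(F)ccc3nc(C(=O)NCc4ccccc4)[nH]c(=O)c23)cc1` gives > 20000 nM as a limit.
- Compound 2 `O=C(O)c1ccc(CCOc2c(F)ccc3nc(C(=O)NCC4CCCCC4)[nH]c(=O)c23)cc1` gives > 20000 nM as a limit.
- Compound 3 `CCc1cccc(CNC(=O)c2nc3ccc(F)c(OCCc4ccc(C(=O)O)cc4)c3c(=O)[nH]2)c1` gives > 20000 nM as a limit.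

Compound 3 therefore has no exact number, only a limit, and it shares that position with both other compounds. Among the measured compounds shown here, the whole series so far is summed up by the limit of > 20000 nM in this assay, at which 3 of the 3 values shown sit, and nothing more.

Compound 4 `CCc1cccc(CN(C)C(=O)c2nc3ccc(F)c(OCCc4ccc(C(=O)O)cc4)c3c(=O)[nH]2)c1` is still unmeasured. It carries methyl in place of hydrogen on an amide-type nitrogen and the difference in full is methyl in place of hydrogen on an amide-type nitrogen in its count.

Three measured steps are available. Cyclohexyl in place of phenyl is a step that the two limits leave unreadable from compound 1 to compound 2 in this series. Ethyl in place of hydrogen on an aromatic carbon is a step that the two limits leave unreadable from compound 1 to compound 3 as well. Replacing cyclohexyl with 3-ethylphenyl is a step that the two limits leave unreadable from compound 2 to compound 3 too. None of them changes the amide hydrogen, and none has a readable size.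

The expectation for compound 4 therefore starts from compound 3 and its > 20000 nM limit. The expected result is a step that the limit leaves unreadable from compound 3 to compound 4 with no shift beyond the scatter expected in either direction in this assay for now. For compound 4 the estimated value is 25000 nM with an expected range from 12000 nM to 50000 nM and a report of only a limit is the likeliest outcome.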

Compound 4, half-maximal cytotoxic concentration: > 20000 nM
Compound 4: a limit, no number; the forecaster's own chance of this, stated with the estimate: 85%; the middle value is on the limit's open side.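

In this assay compound 4 gives > 20000 nM as a limit and not a number. No new step can be read among compound 1, compound 2, compound 3 and compound 4, because all of them share one limit: the limit of > 20000 nM in this assay, at which 4 of the 4 values shown sit. The compounds shown leave open whether methyl on the amide nitrogen changes the cytotoxic concentration at all, and by how much.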